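The source may hold more compounds than are shown below. What is called first, only, known or untested is meant among the compounds shown, and "the series" means these compounds.

Compounds measured in a functional assay on MCF7 cells (Homo sapiens) for inhibition, read by MTT assay, with a stated time of 48 h; a lower number here means a stronger inhibitor, a higher number a weaker inhibitor:
compound 1, `Clc1cccc(CSc2nnc(-c3ccncc3)n2-c2ccccc2)c1`, which in this assay gives 10500 nM
compound 2, `Fc1ccc(CSc2nnc(-c3ccncc3)n2-c2ccccc2)c(F)c1`, which in this assay gives 14100 nM
compound 3, `O=C(CSc1nnc(-c2ccncc2)n1-c1ccccc1)N/N=C/c1ccccc1`, which in this assay gives 23600 nM

Compound 3 stands at the highest of the three numbers. Its gap to compound 2 lies within the scatter, so the two cannot be ordered; its gap to compound 1 lies beyond the scatter, so compound 1 is the stronger inhibitor of that pair. Compound 4, `O=C(CSc1nnc(-c2ccncc2)n1-c1ccccc1)N/N=C/C=C/c1ccccc1`, has not been measured. It differs from compound 3 as follows: 2-phenylethenyl in place of phenyl on a carbon with a double bond to nitrogen.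

Among the compounds with values here, only one measured step is available, a 1.3-fold higher number from compound 1 to compound 2 (0.13 log units; within the scatter), and it concerns the ring on the saturated chain carbon bound to the sulfur, not the carbon with a double bond to nitrogen where compound 4 is altered. That step was within the scatter. Within the data shown here, nothing among the measured compounds speaks to the exchange of phenyl for 2-phenylethenyl itself, so the expectation for compound 4 rests on the value of compound 3 with a wide range. Compound 4 is therefore expected to sit close to compound 3, with an expected step of a 1.0-fold higher number from compound 3 to compound 4 (0.01 log units; within the scatter). The estimate for compound 4 is 24000 nM, with a range from 9000 nM to 65000 nM.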

Compound 4, half-maximal inhibitory concentration: 11200 nM
Estimate against measurement, compound 4: 2.1-fold (0.33 log units) above; the range from low to high includes it.
By their numbers in this assay, from the lowest: compounds 1, 4, 2 and 3 (each within the scatter of the next, the first and the last beyond it).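

In this assay, the carbon with a double bond to nitrogen turns out to be a place where the group matters: putting 2-phenylethenyl in place of phenyl gives a 2.1-fold lower number from compound 3 to compound 4 (0.32 log units; beyond the scatter), a modest step but the first measured at this place. The only earlier step, a 1.3-fold higher number from compound 1 to compound 2 (0.13 log units; within the scatter), concerned the ring on the saturated chain carbon bound to the sulfur, so this is the first single change among these compounds that moves the number beyond the scatter, and it does so with the aromatic ring kept, one double bond outside aromatic rings added, and no hydrogen-bond donors or acceptors on either group. Nothing measured here accounts for the step.

The compounds shown leave open whether the double bond itself counts, which a 2-phenylethyl group on the same carbon would test, or whether a longer chain such as 4-phenylbuta-1,3-dienyl would lower the number further. Also open, going by these compounds, is how a methoxy group or an amine on the phenyl ring of the 2-phenylethenyl group would read in this assay.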